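Notes on the pyridyl-tetrazole series: compound 3

The source may report more compounds than this note shows. Statements on the series, on what has been measured and on what is new or still open speak of the compounds shown alone.

The series shares a core carrying a fluoro group and a tetrazole bearing a pyridin-2-yl, as in compound 1 `N#Cc1ccccc1-c1cc(F)cc(-n2nnc(-c3ccccn3)n2)c1`, which in a functional assay for antagonist activity at metabotropic glutamate receptor 5 (Rattus norvegicus) (on this read-out lower numbers stand for stronger inhibition and higher numbers for weaker inhibition), gives 6 nM. Within the data shown here, compound 2 `Cc1cccnc1-c1cc(F)cc(-n2nnc(-c3ccccn3)n2)c1` carries 3-methylpyridin-2-yl instead and in this assay gives 31 nM; this is the higher of the two numbers measured so far, the step being a 5.2-fold higher number from compound 1 to compound 2 (0.71 log units; beyond the scatter). Compound 3 `Cc1cnccc1-c1cc(F)cc(-n2nnc(-c3ccccn3)n2)c1` is built from the same atoms as compound 2, joined differently: 3-methylpyridin-4-yl in place of 3-methylpyridin-2-yl on an aromatic carbon. Among the measured compounds shown here, no measured step exchanges one pyridyl attachment point for another. For the measured compounds named here, the only step at hand, a 5.2-fold higher number from compound 1 to compound 2 (0.71 log units; beyond the scatter), concerns a different exchange at the same aromatic carbon and shows that changes there can move this assay beyond the scatter, but it gives no direction for the present change. Compound 3 is therefore expected to land close to compound 2. The step expected is a 1.5-fold higher number from compound 2 to compound 3 (0.16 log units; within the scatter), with no direction asserted beyond the scatter and a wide allowance for either side. The estimate for compound 3 in this assay is 45 nM, within 12 nM to 180 nM.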

Compound 3, half-maximal inhibitory concentration: 63 nM
The estimate for compound 3 lay 1.4-fold (0.15 log units) below the measured number; the range from low to high includes it.
By their numbers in this assay, from the lowest: compound 1; then compound 2; then compound 3.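

Among these compounds, changing only how the methylpyridine is joined, with the same atoms present, is not silent at this aromatic carbon: 3-methylpyridin-4-yl in place of 3-methylpyridin-2-yl gives a 2.0-fold higher number from compound 2 to compound 3 (0.31 log units; beyond the scatter) in this assay and is the first measured sign that the attachment point of the ring matters here, though the step is modest. Replacing the 2-cyanophenyl group with 3-methylpyridin-4-yl gives a large step, an 11-fold higher number from compound 1 to compound 3 (1.02 log units; beyond the scatter) and thus a wider gap than any other pair in this set, so both methylpyridines shown give higher numbers than the 2-cyanophenyl group, with no compound here going against that order. Nothing at hand bears on why the two attachment points differ or why either methylpyridine departs from the 2-cyanophenyl group.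

The compounds shown do not separate the contribution of the methyl group from that of the ring nitrogen, or the contribution of the nitrile from that of the phenyl ring that carries it. As far as these compounds go, how this aromatic carbon would respond to a pyridine carrying an amine or a carboxylic acid, or a methoxy group in place of the methyl, also remains open.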